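Anilino versus benzylamino on the shared chloropyrimidine core

The compounds below may be only part of what the source reports. "The series", "measured", "known", "first", "only" and "open" are said of these compounds alone.

Compound 1 `Cc1ccccc1Nc1nc(Nc2ccc(N3CCN(C(=O)OC(C)(C)C)CC3)cc2)ncc1Cl` and compound 2 `COc1ccc(CNc2nc(Nc3ccc(N4CCN(C)CC4)cn3)ncc2Cl)cc1` have been measured in a functional assay on MDA-MB-231 cells (Homo sapiens) for inhibition, read by CCK-8 assay, with a stated time of 48 h; a lower number here means a stronger inhibitor of growth, a higher number a weaker inhibitor of growth. Compound 1 gives 3260 nM there, while compound 2 gives 14900 nM, the higher of the two numbers and beyond the scatter from compound 1. Compound 3 `CCc1ccc(Nc2nc(Nc3ccc(N4CCN(C)CC4)cn3)ncc2Cl)cc1` is not yet measured; it differs from compound 2 by 4-ethylphenyl in place of 4-methoxybenzyl on a nitrogen on an aromatic ring. Since compound 1 also carries an aryl group on that nitrogen and shows 3260 nM, the step of a 3.3-fold lower number from compound 2 to compound 3 (0.52 log units; beyond the scatter) is expected to be a moderate move toward a lower number. Compound 3 is estimated at 4500 nM, range 1300 nM to 15000 nM.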

Compound 3, concentration for 50% growth inhibition: 5560 nM
Estimate against measurement, compound 3: 1.2-fold (0.09 log units) below, and the stated range covers the measured number.
By their numbers in this assay, from the lowest: compounds 1 and 3 (each within the scatter of the next); then compound 2.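

Within the data shown here, on a nitrogen on an aromatic ring, 4-ethylphenyl in place of 4-methoxybenzyl gives a 2.7-fold lower number from compound 2 to compound 3 (0.43 log units; beyond the scatter) in this assay, the first one-place step. This single step removes the methylene link and exchanges methoxy for ethyl together, so neither part can be credited alone. No supporting data explain the step. On these data alone, whether 4-methoxyphenyl or 4-ethylbenzyl on that nitrogen would separate the two parts stays open. As far as these compounds go, how a longer chain, such as 4-propylphenyl, would read there also stays open.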